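Cycloalkyl ethers in the series: working notes

A few compounds are considered here, and "the series" means these few. Any claim that something is new, unique, unknown or untested is made for them only; others in the source may bear on it.

Compound 1 `c1cc(C2CCCCC2)ccc1NC1=NCCO1`: 12800 nM
Compound 2 `c1cc(OC2CCCC2)ccc1NC1=NCCO1`: 16100 nM

For the measured compounds named here, in a functional assay on HT-29 cells (Homo sapiens) for inhibition, read by sulforhodamine B assay, with a stated time of 48 h (on this read-out lower numbers stand for stronger inhibition of growth and higher numbers for weaker inhibition of growth), compound 2 gives 16100 nM, within the scatter of compound 1, the only other measured compound. Compound 3 `c1cc(OC2CCCCC2)ccc1NC1=NCCO1` differs from compound 2 by cyclohexyl in place of cyclopentyl on an oxygen on an aromatic ring. Going by the values given here, the only measured step that bears on this change, a 1.3-fold higher number from compound 1 to compound 2 (0.10 log units; within the scatter), stayed within the scatter. No change beyond the scatter is therefore expected in this assay. The expected step is a 1.2-fold lower number from compound 2 to compound 3 (0.08 log units; within the scatter). For compound 3 the estimate is 13500 nM, with an expected range of 7000 nM to 26000 nM.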

Compound 3, concentration for 50% growth inhibition: 12600 nM
Estimate against measurement, compound 3: 1.1-fold (0.03 log units) above; the measured number falls inside the stated range.
By their numbers in this assay, from the lowest: compounds 3, 1 and 2 (each within the scatter of the next).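

Cyclohexyl in place of cyclopentyl on an oxygen on an aromatic ring gives a 1.3-fold lower number from compound 2 to compound 3 (0.11 log units; within the scatter) in this assay. For the compounds shown here, this is the first step read at the ring on the oxygen itself, and it shows that the five-membered and six-membered rings cannot be told apart at this position in this assay. No measurement bears on a reason for this result.

Still open, on these data alone, is whether an amine, a carboxylic acid or a longer chain on this oxygen would give a step beyond the scatter. Also open, as far as these compounds go, is whether the cyclohexyl and cyclopentyl ethers stay this close in any other assay.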